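Naphthalen-1-yl replaces 4-(trifluoromethyl)phenyl: compound 3 to compound 4

The source may report more compounds than this note shows. Statements on the series, on what has been measured and on what is new or still open speak of the compounds shown alone.

In a functional assay on BT-483 cells (Homo sapiens) for cytotoxicity, read by MTT assay, with a stated time of 24 h (a lower number here means a stronger inhibitor, a higher number a weaker inhibitor), compound 3 (`CCNc1cc(-c2ccc(NC(=O)Nc3ccc(C(F)(F)F)cc3)cc2C(F)(F)F)ccn1`) gives 16400 nM and compound 2 (`CCNc1cc(-c2ccc(NC(=O)Nc3cccc(Cl)c3)cc2C(F)(F)F)ccn1`) gives 13300 nM, two numbers that lie within the scatter of each other. For the measured compounds named here, the only other compound measured, compound 1 (`CCNc1cc(-c2ccc(NC(=O)Nc3cccc4ccccc34)cc2C)ccn1`), carries naphthalen-1-yl on the amide-type nitrogen, with methyl where compound 3 has trifluoromethyl. Compound 1 returns only a limit, > 30000 nM, and not a number.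

Compound 4 (`CCNc1cc(-c2ccc(NC(=O)Nc3cccc4ccccc34)cc2C(F)(F)F)ccn1`) is still to be measured. It has naphthalen-1-yl in place of the 4-(trifluoromethyl)phenyl of compound 3 on an amide-type nitrogen: naphthalen-1-yl in place of 4-(trifluoromethyl)phenyl on an amide-type nitrogen. Going by the values given here, one measured step bears directly on this place: exchanging 3-chlorophenyl for 4-(trifluoromethyl)phenyl gave a 1.2-fold higher number from compound 2 to compound 3 (0.09 log units; within the scatter). That exchange shows a change of aryl group at this nitrogen leaving the number in the scatter, whereas the limit seen for compound 1 leaves room for a weaker result, and compound 4 might also end at a limit.

The expected outcome in this assay is therefore no step beyond the scatter, with an estimated 1.2-fold higher number from compound 3 to compound 4 (0.09 log units; within the scatter). Compound 4 is expected at 20000 nM, with an estimated range of 9000 nM to 30000 nM.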

Compound 4, half-maximal inhibitory concentration: > 30000 nM
Compound 4 was reported as a limit; the forecaster's own chance of this, stated with the estimate: 35%; middle value at least 1.5-fold (0.17 log units) away from the limit.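

In this assay, for the compounds shown here, naphthalen-1-yl on the amide-type nitrogen is the first exchange at this place to give a step that can be read as beyond the scatter: an at least 2.2-fold higher number from compound 2 to compound 4 (0.35 log units; beyond the scatter). Against the other aryl group the result is less firm, with an at least 1.8-fold higher number from compound 3 to compound 4 (0.26 log units; that floor lies within the scatter), so the floor alone does not separate compound 3 from compound 4, although the earlier exchange between 3-chlorophenyl and 4-(trifluoromethyl)phenyl had shown no step beyond the scatter. Compound 1 had left naphthalen-1-yl paired with methyl, but with trifluoromethyl kept in place the naphthalen-1-yl compound again returns only a limit, and the step between compound 1 and compound 4 cannot be read, so the effect of that methyl exchange stays unknown: the limit of > 30000 nM in this assay, at which 2 of the 4 values shown sit.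

With no number for compound 4, the true size of either step remains unknown, and the compounds shown do not separate the second aromatic ring of naphthalen-1-yl from the loss of the chlorine or trifluoromethyl substituent. On these data alone, it also remains open whether a phenyl carrying an amine or a carboxylic acid at this nitrogen would return a number in this assay.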